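Sarcosine Tail on a Folate-Type Thymidylate Synthase Inhibitor

A few compounds are considered here, and "the series" means these few. Any claim that something is new, unique, unknown or untested is made for them only; others in the source may bear on it.

Compound 1 `C#CCN(Cc1ccc2nc(C)nc(O)c2c1)c1ccc(C(=O)N[C@@H](CCC(=O)O)C(=O)N2CCCC2C(=O)O)cc1`: 35 nM
Compound 2 `C#CCN(Cc1ccc2nc(C)nc(O)c2c1)c1ccc(C(=O)N[C@@H](CCC(=O)O)C(=O)N(C)[C@@H](CCC(=O)O)C(=O)O)cc1`: 11 nM
Compound 3 `C#CCN(Cc1ccc2nc(C)nc(O)c2c1)c1ccc(C(=O)N[C@@H](CCC(=O)O)C(=O)NC(C)(C)C(=O)O)cc1`: 42 nM

Three compounds sharing one core, measured in an assay on L1210 cells for inhibition of Thymidylate synthase (Mus musculus) (a higher number here means a weaker inhibitor, a lower number a stronger inhibitor), differ only in the group attached to the terminal carbonyl carbon. Compound 3 gives the highest number of the three. Its nearest neighbour is compound 1, and the step of a 1.2-fold higher number from compound 1 to compound 3 (0.08 log units; within the scatter) lies within the scatter, so the two cannot be ordered. The gap to compound 2 is larger: a 3.8-fold higher number from compound 2 to compound 3 (0.58 log units; beyond the scatter), a modest but real difference.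

Compound 4 `C#CCN(Cc1ccc2nc(C)nc(O)c2c1)c1ccc(C(=O)N[C@@H](CCC(=O)O)C(=O)N(C)CC(=O)O)cc1` has not yet been measured. It differs from compound 3 in one place: (carboxymethyl)(methyl)amino in place of (1-carboxy-1-methylethyl)amino on a carbonyl carbon.

The measured steps bearing on this change are a 1.2-fold higher number from compound 1 to compound 3 (0.08 log units; within the scatter) and a 3.8-fold higher number from compound 2 to compound 3 (0.58 log units; beyond the scatter). Compound 2, which carries a methyl on the amide nitrogen like compound 4 does, gives the lowest number, but compound 4 lacks the second carboxylic acid of compound 2. Compound 4 is therefore expected to land close to compound 3, with at most a modest improvement: a 1.4-fold lower number from compound 3 to compound 4 (0.15 log units; within the scatter). The estimate for compound 4 is 30 nM, within a range from 12 nM to 75 nM.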

Compound 4, inhibition constant: 50 nM
For compound 4 the middle estimate is 1.7-fold (0.22 log units) below the measured one; low and high end bracket the measured number.
By their numbers in this assay, from the lowest: compound 2; then compounds 1, 3 and 4 (each within the scatter of the next).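

In this assay, replacing the gem-dimethyl tail of compound 3 with the tail that carries a methyl on the nitrogen gives a 1.2-fold higher number from compound 3 to compound 4 (0.08 log units; within the scatter), and the comparison with the proline-type tail gives a 1.4-fold higher number from compound 1 to compound 4 (0.15 log units; within the scatter), so neither change separates these compounds. Taking away only the 2-carboxyethyl group gives a 4.5-fold higher number from compound 2 to compound 4 (0.66 log units; beyond the scatter), which shows that, among these compounds, the methyl on the nitrogen is not enough to reach the low number of compound 2; that number goes with the 2-carboxyethyl group. Nothing measured here explains this link.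

On these data alone, it remains open whether the 2-carboxyethyl group keeps that low number with the amide hydrogen in place of the methyl. As far as these compounds go, it is also open whether a longer chain ending in a carboxylic acid, or a chain ending in an amine, would serve in its place.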